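Replacing the 2-carboxyethyl group of compound 2

A few compounds are considered here, and "the series" means these few. Any claim that something is new, unique, unknown or untested is made for them only; others in the source may bear on it.

In a functional assay on NCI-H1975 cells (Homo sapiens) for cytotoxicity, read by MTT assay, with a stated time of 72 h (a lower number here means a stronger inhibitor, a higher number a weaker inhibitor), compound 1 `COc1cc(/C=C2\CN(C)C/C(=C\c3cc(OC)c(OC)c(OC)c3)C2=O)cc(OC)c1OC` gives 1000 nM. Compound 2 `COc1cc(/C=C2\CN(C(=O)CCC(=O)O)C/C(=C\c3cc(OC)c(OC)c(OC)c3)C2=O)cc(OC)c1OC` gives > 60000 nM, which is a limit and not a number. Its place among the values shown is the limit of > 60000 nM in this assay, at which 1 of the 2 values shown sits. Compound 3 `COc1cc(/C=C2\CN(C(=O)c3ccccc3F)C/C(=C\c3cc(OC)c(OC)c(OC)c3)C2=O)cc(OC)c1OC` carries 2-fluorophenyl in place of 2-carboxyethyl on a carbonyl carbon. Going by the values given here, only one measured step bears on this change: an at least 60-fold higher number from compound 1 to compound 2 (1.77 log units; beyond the scatter), a large step beyond the scatter, with (2-carboxyethyl)carbonyl in place of methyl on an amine nitrogen in a ring. Among the compounds with values here, the 2-carboxyethyl group that arrived in that step now leaves, although the carbonyl stays and no measured compound carries 2-fluorophenyl. A large step towards a lower number is therefore expected in this assay. The estimated change is an at least 24-fold lower number from compound 2 to compound 3 (1.38 log units; beyond the scatter). For compound 3 the estimated value is 2500 nM, with an expected range from 600 nM to 12000 nM.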

Compound 3, half-maximal inhibitory concentration: 1400 nM
Beside the measured number, compound 3's estimate is 1.8-fold (0.25 log units) above it; measured number inside the range.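

In this assay, with the carbonyl kept, 2-fluorophenyl in place of 2-carboxyethyl gives an at least 42-fold lower number from compound 2 to compound 3 (1.63 log units; beyond the scatter), so the carbonyl on the amide-type nitrogen in a ring does not by itself carry the earlier loss. Against the methyl group of the first compound, (2-fluorophenyl)carbonyl gives a 1.4-fold higher number from compound 1 to compound 3 (0.15 log units; within the scatter), so the two compounds of that step stand level within the scatter. Compound 2 remains a limit and not a number, which leaves the full size of its steps unknown: the limit of > 60000 nM in this assay, at which 1 of the 3 values shown sits.

The compounds shown leave open whether the loss goes with the carboxylic acid itself or with the chain that carries it, a question that a methyl ester or a plain butanoyl group would address. They also leave open what the fluorine contributes compared with an unsubstituted phenyl.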